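The source may hold more compounds than are shown below. What is called first, only, known or untested is meant among the compounds shown, and "the series" means these compounds.

Measured so far in an assay on HT-29 cells for inhibition of Methylated-DNA--protein-cysteine methyltransferase (Homo sapiens); on this read-out lower numbers stand for stronger inhibition and higher numbers for weaker inhibition:
compound 1, `CCCCCCCOc1nc(N)nc2[nH]cnc12`: > 100000 nM
compound 2, `Nc1nc(OCCc2ccccc2)c2nc[nH]c2n1`: 548000 nM
compound 3, `CCC(COc1nc(N)nc2[nH]cnc12)(OC)OC`: > 1000000 nM

Compound 1 has no number of its own in this assay, only the limit given by the limit of > 100000 nM in this assay, at which 1 of the 3 values shown sits. Compound 3 sits likewise at a limit, the one given by the limit of > 1000000 nM in this assay, at which 1 of the 3 values shown sits. Among the measured compounds shown here, compound 2 is the one member of the set with a resolved value, and that value places it in the weakly inhibiting region of this assay. For the measured compounds named here, the one step that can be paired, a step that the limit leaves unreadable from compound 1 to compound 2, cannot be sized because the limit of > 100000 nM in this assay, at which 1 of the 3 values shown sits, caps compound 1; its direction is not readable either.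

Compound 4, `CC(=O)COc1nc(N)nc2[nH]cnc12`, differs from compound 1 by acetyl in place of hexyl on a saturated chain carbon bound to an oxygen on an aromatic ring. Going by the values given here, no measured step touches this change: the only paired step in the set alters the far end of the chain, two bonds along from the aryl oxygen, and is itself unreadable. With a limit at compound 1 and nothing in the set pointing to a resolved gain, compound 4 is expected to remain in the weak region, with a fair chance of another limit rather than a number. The estimate for compound 4 is 500000 nM, within 100000 nM to 3000000 nM. Expressed as a step, the expected move is a step that the limit leaves unreadable from compound 1 to compound 4, an estimate only.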

Compound 4, half-maximal inhibitory concentration: 192000 nM
Compound 4: middle estimate off by 2.6-fold (0.42 log units), on the high side; low and high end bracket the measured number.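

The step from compound 1 to compound 4 cannot be read, in size or direction, since compound 1 carries a limit and not a number: the limit of > 100000 nM in this assay, at which 1 of the 4 values shown sits.

The compounds shown leave open how far, and in which direction, acetyl in place of hexyl on a saturated chain carbon bound to an oxygen on an aromatic ring moves inhibition on the shared core.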